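The compounds below may be only part of what the source reports. "The series", "measured", "known", "first", "only" and "open" are said of these compounds alone.

Measured compounds, with their potency in a functional assay on A549 cells (Homo sapiens) for cytotoxicity, read by MTT assay, with a stated time of 72 h; a higher number here means a weaker inhibitor, a lower number a stronger inhibitor:

compound 1, `CCN(CC)CCCOc1c(OCc2ccccc2)cc(O)c2c(=O)cc(-c3ccccc3)oc12`, which gives 3620 nM
compound 2, `O=c1cc(-c2ccccc2)oc2c(OCCCCN3CCCC3)c(OCc3ccccc3)cc(O)c12`, which gives 1100 nM
compound 3, `CN1CCN(CCCCOc2c(OCc3ccccc3)cc(O)c3c(=O)cc(-c4ccccc4)oc23)CC1`, which gives 2910 nM

Among these three, compound 3 stands second highest. Its nearest neighbour is compound 1: the step of a 1.2-fold lower number from compound 1 to compound 3 (0.09 log units; within the scatter) is too small to count as a real difference. Compound 2 sits clearly lower; the step of a 2.6-fold higher number from compound 2 to compound 3 (0.42 log units; beyond the scatter) lies beyond the scatter, so compound 2 is the stronger inhibitor of those two.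

The next compound, compound 4 (`CN1CCN(CCCCOc2c(OCc3cccs3)cc(O)c3c(=O)cc(-c4ccccc4)oc23)CC1`), keeps everything from compound 3 except one group: thiophen-2-yl in place of phenyl on a saturated chain carbon bound to an oxygen on an aromatic ring. All three measured steps, a 3.3-fold lower number from compound 1 to compound 2 (0.52 log units; beyond the scatter), a 1.2-fold lower number from compound 1 to compound 3 (0.09 log units; within the scatter) and a 2.6-fold higher number from compound 2 to compound 3 (0.42 log units; beyond the scatter), changed only the amine at the end of the other chain, so none of them touches the group swapped here. The largest of them was modest, and the shared core and both chains are otherwise kept. Within the data shown here, with no step that bears directly on this change, the expected step of a 1.0-fold higher number from compound 3 to compound 4 (0.01 log units; within the scatter) is small, with no firm direction. Compound 4 is therefore estimated at 3000 nM, within a range of 1200 nM to 7500 nM.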

Compound 4, half-maximal inhibitory concentration: 2100 nM
The estimate for compound 4 lay 1.4-fold (0.15 log units) above the measured number; the measured number falls inside the stated range.
By their numbers in this assay, from the lowest: compounds 2, 4, 3 and 1 (each within the scatter of the next, the first and the last beyond it).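

Up to now, every step changed only the amine at the end of the other chain, so the step of a 1.4-fold lower number from compound 3 to compound 4 (0.14 log units; within the scatter) in this assay is the only one here that bears on the group on a saturated chain carbon bound to an oxygen on an aromatic ring. Swapping phenyl for thiophen-2-yl exchanges a six-membered aromatic ring of carbon only for a five-membered aromatic ring holding a sulfur atom, which adds a hydrogen-bond acceptor, yet compound 3 and compound 4 cannot be told apart in this assay, so with the 4-methylpiperazin-1-yl chain in place, this position accepts the swap without a real difference in the number. Nothing measured here explains this result.

Whether the same swap would also leave the number unchanged on the pyrrolidin-1-yl chain of compound 2 remains an open question. Also open, going by these compounds, is whether a more different group in place of the phenyl, such as a plain methyl or a pyridine ring, would give a step beyond the scatter.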